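Chloro to trifluoromethyl on the aryl piperazine of compound 2

The source may report more compounds than this note shows. Statements on the series, on what has been measured and on what is new or still open speak of the compounds shown alone.

Compound 1 `O=C1C2CCCCN2C(=O)N1CCCN1CCN(c2ccccc2)CC1`: 11.4 nM in an assay on isolated protein for binding affinity to Adrenergic receptor alpha-1 (Rattus norvegicus), read by radioligand binding; on this read-out lower numbers stand for stronger inhibition and higher numbers for weaker inhibition
Compound 2 `O=C1C2CCCCN2C(=O)N1CCCN1CCN(c2cccc(Cl)c2)CC1`: 17.9 nM in this assay

Of the two measured compounds, compound 2 has the higher number, and the step of a 1.6-fold higher number from compound 1 to compound 2 (0.20 log units; within the scatter) lies within the scatter. Compound 3 `O=C1C2CCCCN2C(=O)N1CCCN1CCN(c2cccc(C(F)(F)F)c2)CC1` differs from compound 2 by trifluoromethyl in place of chloro on an aromatic carbon. Going by the values given here, the only measured step, that from compound 1 to compound 2, is a small one, and the change to compound 3 likewise touches one substituent on the same aromatic carbon; no larger effect is therefore expected, with the step of a 1.4-fold higher number from compound 2 to compound 3 (0.15 log units; within the scatter) estimated to stay within or only just beyond the scatter. For compound 3 the expected value in this assay is 25 nM, within 10 nM to 60 nM.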

Compound 3, inhibition constant: 90.4 nM
Estimate against measurement, compound 3: 3.6-fold (0.56 log units) below; the whole stated range lies below it.
By their numbers in this assay, from the lowest: compounds 1 and 2 (each within the scatter of the next); then compound 3.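

Trifluoromethyl on the aromatic carbon meta to a large group gives a 5.1-fold higher number from compound 2 to compound 3 (0.70 log units; beyond the scatter) in this assay, so this place does not treat its substituents alike. Measured against hydrogen, the same group gives a 7.9-fold higher number from compound 1 to compound 3 (0.90 log units; beyond the scatter), whereas the step to chloro stayed within the scatter. Nothing available explains why the two substituents part in this way. From the compounds shown here alone, whether a methoxy group or a nitrile on this carbon would follow chloro or trifluoromethyl stays open, as does how either substituent would behave on another carbon of the ring.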